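From nitrobenzyl to fluorobenzyl ether

This account rests on a few compounds, and the source may have more. Where it says the series, first, only, none or still open, it means among the compounds named here.

Measured in a functional assay on U-251 cells (Homo sapiens) for antiproliferative activity, read by MTT assay, with a stated time of 24 h; on this read-out lower numbers stand for stronger inhibition and higher numbers for weaker inhibition:
compound 1 `COc1cc(OC)c(-c2coc3cc(OCC=C(C)C)ccc3c2=O)cc1OC` gives 3500 nM here
compound 2 `COc1cc(OC)c(-c2coc3cc(OCc4ccc([N+](=O)[O-])cc4)ccc3c2=O)cc1OC` gives 9400 nM here

Compound 2 holds the higher of the two numbers, so it is the weaker inhibitor of the pair. Compound 3 `COc1cc(OC)c(-c2coc3cc(OCc4cccc(F)c4)ccc3c2=O)cc1OC` differs from it as follows: 3-fluorophenyl in place of 4-nitrophenyl on a saturated chain carbon bound to an oxygen on an aromatic ring and nothing else changes. Among the compounds with values here, one measured step bears on this place, a 2.7-fold higher number from compound 1 to compound 2 (0.43 log units; beyond the scatter) and it involves 4-nitrophenyl but not 3-fluorophenyl. Within the data shown here, a modest move toward a lower number is therefore expected, no larger than that step. The expected step is a 1.6-fold lower number from compound 2 to compound 3 (0.19 log units; within the scatter) in this estimate. Compound 3 is estimated at 6000 nM within an expected range of 2500 nM to 14000 nM in this assay here.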

Compound 3, half-maximal inhibitory concentration: 3510 nM
Compound 3: middle estimate off by 1.7-fold (0.23 log units), on the high side, and the stated range covers the measured number.
By their numbers in this assay, from the lowest: compounds 1 and 3 (each within the scatter of the next); then compound 2.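

In this assay, replacing 4-nitrophenyl with 3-fluorophenyl on this saturated chain carbon gives a 2.7-fold lower number from compound 2 to compound 3 (0.43 log units; beyond the scatter), so the weaker result of compound 2 is not shared by every benzyl ether here. Set against the prenyl-type ether, the same group gives a 1.0-fold higher number from compound 1 to compound 3 (0.00 log units; within the scatter), which shows that an aromatic ring at this place can stand level with the 2-methylprop-1-en-1-yl group. No evidence is available to explain these steps. The compounds shown do not separate the change of group from the change of its place on the ring, and how a benzyl ether carrying an amine or a carboxylic acid would read here remains open.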